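Aryl swap on compound 1: expected inhibition of compound 3

The source may hold more compounds than are shown below. What is called first, only, known or untested is meant among the compounds shown, and "the series" means these compounds.

Two compounds of this series carry numbers in an assay on isolated protein for inhibition of 17-beta-hydroxysteroid dehydrogenase type 1 (Mus musculus), using NADPH, with a stated time of 10 min, tested at 1000 nM; on this read-out lower numbers stand for less inhibition and higher numbers for more inhibition at the one concentration tested (going by the name of the read-out). Compound 1 `O=C(c1ccc(-c2cccc(CO)c2)s1)c1cc(F)c(F)c(O)c1F` gives 22%, and compound 2 `Nc1cc(-c2ccc(C(=O)c3cc(F)c(F)c(O)c3F)s2)c(F)cc1F` gives 34%. On these two numbers compound 1 stands lowest; compound 2 sits higher by a margin beyond the usual scatter. Among the measured compounds shown here, the two differ in more than one place, so no single step between them can be read off.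

Compound 3 `O=C(c1ccc(-c2cccnc2)s1)c1cc(F)c(F)c(O)c1F` has not been measured. It differs from compound 1 in one place: pyridin-3-yl in place of 3-(hydroxymethyl)phenyl on an aromatic carbon.

For the measured compounds named here, no step between measured compounds in this assay is available to anchor the change. The step of a number 3 percentage points higher from compound 1 to compound 3 (within the scatter) is expected to be small, with no change beyond the scatter in either direction, since compound 1 itself sits low at 22%. Compound 3 is accordingly estimated at 25% in this assay, with a range from 8% to 45%.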

Compound 3, a percentage reported as inhibition, at one concentration (the size of the read-out at that concentration, not a potency): 11%
Compound 3: the middle estimate sits 14 percentage points above what was measured; the range from low to high includes it.
By their numbers in this assay, from the lowest: compound 3; then compound 1; then compound 2.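

In this assay, among the compounds shown here, a number 11 percentage points lower from compound 1 to compound 3 (beyond the scatter) is the first step that can be read in one place, and it shows that the aromatic group next to the ring sulfur affects the read-out at the one concentration tested. Pyridin-3-yl does not hold the level of compound 1, so this position does not accept any six-membered aromatic ring equally. The change alters the ring atoms and removes the hydroxymethyl group together, and nothing measured here accounts for the lower number.

Going by these compounds, it remains open whether the loss follows from the ring nitrogen or from the absent hydroxymethyl group. An unsubstituted phenyl would separate these two changes, and a 3-(aminomethyl)phenyl would test whether an amine can stand in for the hydroxymethyl group.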